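The source may report more compounds than this note shows. Statements on the series, on what has been measured and on what is new or still open speak of the compounds shown alone.

In a functional assay on CCRF-CEM cells (Homo sapiens) for antiproliferative activity, read by sulforhodamine B assay, with a stated time of 48 h (a higher number here means a weaker inhibitor, a lower number a stronger inhibitor), compound 1 (`O=C(NCCCNc1cc(-c2cn(-c3ccccc3)nc2-c2cccc(O)c2)ccn1)Nc1ccc(F)cc1`) gives 1420 nM and compound 2 (`O=C(NCCCNc1cc(-c2cn(-c3ccccc3)nc2-c2cccc(O)c2)ccn1)Nc1cccc(C(F)(F)F)c1`) gives 1710 nM in the same test. The two numbers sit together, and compound 1 has no other measured neighbour. Going by the values given here, the one measured step (a 1.2-fold higher number from compound 1 to compound 2 (0.08 log units; within the scatter)) replaces the aryl group on an amide-type nitrogen and stays within the scatter.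

Compound 3 (`COc1cccc(-c2nn(-c3ccccc3)cc2-c2ccnc(NCCCNC(=O)Nc3ccc(F)cc3)c2)c1`) differs from compound 1 at another place (methyl in place of hydrogen on an oxygen on an aromatic ring): methyl in place of hydrogen on an oxygen on an aromatic ring, which turns 3-hydroxyphenyl into 3-methoxyphenyl. Among the compounds with values here, no measured step touches this oxygen, and both measured compounds carry the hydroxy group, so the step from compound 1 to compound 2 is only a weak guide. A modest move toward a higher number is expected, though it may not clear the scatter. The expected step is a 1.6-fold higher number from compound 1 to compound 3 (0.21 log units; within the scatter) and rests on little direct evidence. The estimate for compound 3 is 2300 nM with a range from 800 nM to 6500 nM kept wide.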

Compound 3, half-maximal inhibitory concentration: 8530 nM
Compound 3: middle estimate off by 3.7-fold (0.57 log units), on the low side; measured number outside the range, above it.
By their numbers in this assay, from the lowest: compounds 1 and 2 (each within the scatter of the next); then compound 3.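

In this assay, going by these compounds alone, the change from hydroxy to methoxy gives a 6.0-fold higher number from compound 1 to compound 3 (0.78 log units; beyond the scatter) and is the first step here that lies beyond the scatter, whereas the earlier step of a 1.2-fold higher number from compound 1 to compound 2 (0.08 log units; within the scatter) on the aryl group on the amide-type nitrogen stays within it. The oxygen on the aromatic ring is therefore a place where a single added methyl moves the number clearly, and in this pair the free hydroxy group goes with the lower number, the stronger inhibitor. No measurement of any other kind accompanies these numbers, so the compounds shown offer no explanation for this step.

As far as these compounds go, the step is read only on compounds carrying the 4-fluorophenyl group, so whether the same methyl has a comparable effect alongside the 3-(trifluoromethyl)phenyl group of compound 2 remains open. Also open, from the compounds shown here alone, is what a different group at this place would do, such as an ethyl on the oxygen, or an amine or a fluorine in place of the hydroxy group, and whether any of these would stay close to compound 1 or move toward compound 3.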